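This account rests on a few compounds, and the source may have more. Where it says the series, first, only, none or still open, it means among the compounds named here.

Measured so far:
Compound 1 `CCc1cc(C(C)=O)c(O)cc1OCCCCCCC#N` — 103%
Compound 2 `CCc1cc(C(C)=O)c(O)cc1OCCCCCC(C)(C)C#N` — 85%

In an assay on isolated protein for inhibition of leukotriene B4 receptor 1 (Homo sapiens), tested at 10 uM (on this read-out higher numbers stand for more inhibition at the one concentration tested (going by the name of the read-out) and lower numbers for less inhibition), compound 1 gives 103%, whereas compound 2 gives 85%. Among the compounds with values here, compound 2 thus stands lowest of the two numbers, and the one measured step, a number 18 percentage points lower from compound 1 to compound 2 (beyond the scatter), separates it from compound 1 beyond the scatter. That step concerns the end of the chain, where 1-cyano-1-methylethyl replaces cyanomethyl on a saturated chain carbon five bonds along the chain from an oxygen on the aromatic ring.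

Compound 3 `CC(=O)c1cc(C(C)(C)C)c(OCCCCCC(C)(C)C#N)cc1O` differs from compound 2 at another site: tert-butyl in place of ethyl on an aromatic carbon, on an aromatic carbon of the six-membered aromatic ring of carbon only, ortho to the large group, meta to the acetyl group and para to the hydroxy group. Within the data shown here, no measured step touches this position; both measured compounds carry ethyl there, so the data give no direct guide. The shared 1-cyano-1-methylethyl chain end of compound 2 and compound 3 is the only anchor. He therefore expects no step beyond the scatter, a number 5 percentage points lower from compound 2 to compound 3 (within the scatter), with a wide margin. Compound 3 is estimated at 80%, between 50% and 100%.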

Compound 3, a percentage reported as inhibition, at one concentration (the size of the read-out at that concentration, not a potency): 1%
Compound 3: middle estimate off by 79 percentage points, on the high side; measured number below the stated range.
By their numbers in this assay, from the lowest: compound 3; then compound 2; then compound 1.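

In this assay, putting tert-butyl in place of ethyl on the aromatic carbon ortho to a large group, meta to an acetyl group and para to a hydroxy group gives a number 84 percentage points lower from compound 2 to compound 3 (beyond the scatter), so this position, which carried ethyl in both earlier compounds, turns out to matter greatly for the read-out. The change at the chain end gave only a number 18 percentage points lower from compound 1 to compound 2 (beyond the scatter), whereas here the substituent goes from 2 heavy atoms to 4 heavy atoms, all carbon, with no hydrogen-bond donor, acceptor or net charge on either side, and nearly all of the inhibition is lost. Nothing at hand accounts for a loss of this size.

On these data alone, with only ethyl and tert-butyl seen at this position, it remains open whether an isopropyl or a methyl group would stay near compound 2 at 85% or fall toward compound 3 at 1%. As far as these compounds go, it is also open whether tert-butyl would cost as much on the unbranched nitrile chain of compound 1, and how a carboxylic acid at the chain end would read in this assay.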